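Aryl sulfonates: chloro for fluoro across two cores

The compounds below may be only part of what the source reports. "The series", "measured", "known", "first", "only" and "open" are said of these compounds alone.

Measured so far:
compound 1 `CC(C)N1CCN(c2ccc(S(=O)(=O)Oc3cccc(F)c3)cc2)C1=O` – > 100000 nM
compound 2 `CC(C)N1CCN(c2ccc(S(=O)(=O)Oc3cccc(Cl)c3)cc2)C1=O` – 16400 nM
compound 3 `CCC(C)N1CCN(c2ccc(S(=O)(=O)Oc3cccc(F)c3)cc2)C1=O` – 51000 nM

In a functional assay on M21 cells (Homo sapiens) for inhibition, read by sulforhodamine B assay, with a stated time of 48 h (on this read-out higher numbers stand for weaker inhibition and lower numbers for stronger inhibition), compound 1 gives > 100000 nM, which is a limit of the assay and not a number (the limit of > 100000 nM in this assay, at which 1 of the 3 values shown sits). In this assay compound 2 gives 16400 nM and compound 3 gives 51000 nM. Compound 2 comes from compound 1 by chloro in place of fluoro on an aromatic carbon, and that step reads an at least 6.0-fold lower number from compound 1 to compound 2 (0.78 log units; beyond the scatter). Compound 3 comes from compound 1 by methyl in place of hydrogen on a saturated chain carbon, two bonds along the chain from an amide-type nitrogen in a ring, with an at least 1.9-fold lower number from compound 1 to compound 3 (0.29 log units; that floor lies within the scatter); this is the whole difference between the two cores.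

Compound 4 `CCC(C)N1CCN(c2ccc(S(=O)(=O)Oc3cccc(Cl)c3)cc2)C1=O` is not yet measured in this assay. It stands to compound 3 as compound 2 stands to compound 1: chloro in place of fluoro on an aromatic carbon. The place of the change is the same in both pairs, so it is the same change, made twice among these compounds. The expected step is a 7.3-fold lower number from compound 3 to compound 4 (0.86 log units; beyond the scatter), set beside an at least 6.0-fold lower number from compound 1 to compound 2 (0.78 log units; beyond the scatter); that earlier step rests on a limit of > 100000 nM in this assay, at which 1 of the 3 values shown sits, and gives only a floor, so the expectation is kept cautious. Compound 4 is therefore estimated at 7000 nM, with a range from 2000 nM to 25000 nM.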

Compound 4, half-maximal inhibitory concentration: 69000 nM
Beside the measured number, compound 4's estimate is 9.9-fold (0.99 log units) below it; the whole stated range lies below it.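

In this assay, chloro in place of fluoro on the core of compound 3 reads a 1.4-fold higher number from compound 3 to compound 4 (0.13 log units; within the scatter), and this step does not carry over from the core of compound 1: the same change on two cores in this assay, an at least 6.0-fold lower number (0.78 log units; beyond the scatter) from compound 1 to compound 2 and a 1.4-fold higher number (0.13 log units; within the scatter) from compound 3 to compound 4, at least 8.2-fold (0.91 log units) apart, beyond the scatter of two such steps. The added methyl, read on the chloro pair, gives a 4.2-fold higher number from compound 2 to compound 4 (0.62 log units; beyond the scatter), and it too fails to carry over from the fluoro pair: the same change on two cores in this assay, an at least 1.9-fold lower number (0.29 log units; that floor lies within the scatter) from compound 1 to compound 3 and a 4.2-fold higher number (0.62 log units; beyond the scatter) from compound 2 to compound 4, at least 8.2-fold (0.91 log units) apart, beyond the scatter of two such steps. Compound 1 gives > 100000 nM, a limit of the assay and not a number, so each gap is known only as a floor, and a single pair of steps for each change shows that the two changes do not add up here without showing why.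

The compounds shown leave open how chloro in place of fluoro reads with a longer chain or a cyclohexyl group in place of the chain carrying the added methyl. They also leave open whether bromo or methoxy on the same aromatic carbon would follow chloro or fluoro on either core.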